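Triazole-linked diaryl ureas: ethyl to isopropyl on the phenyl

This account rests on a few compounds, and the source may have more. Where it says the series, first, only, none or still open, it means among the compounds named here.

Measured in a functional assay on HepG2 cells (Homo sapiens) for inhibition, read by MTT assay, with a stated time of 72 h; a higher number here means a weaker inhibitor, a lower number a stronger inhibitor:
compound 1, `N#Cc1ccccc1-n1cc(COc2cccc(NC(=O)Nc3ccc(Cl)c(C(F)(F)F)c3)c2)nn1`: 1970 nM
compound 2, `CCc1cccc(-n2cc(COc3cccc(NC(=O)Nc4ccc(Cl)c(C(F)(F)F)c4)c3)nn2)c1`: 37900 nM

Going by the values given here, compound 2 stands at the highest of the two numbers in this assay; its nearest neighbour is compound 1, and the step of a 19-fold higher number from compound 1 to compound 2 (1.28 log units; beyond the scatter) is the only measured step in the set. Compound 3, `CC(C)c1cccc(-n2cc(COc3cccc(NC(=O)Nc4ccc(Cl)c(C(F)(F)F)c4)c3)nn2)c1`, differs from compound 2 by methyl in place of hydrogen on a saturated chain carbon bound to an aromatic carbon and a saturated chain carbon.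

That single measured step exchanges the whole aryl substituent on the triazole nitrogen, so it does not speak directly to a change within the ethyl chain of compound 2. Among the compounds with values here, with no measured pair that varies the chain alone, the expectation for this assay rests on the scale of the change: one carbon added, no new donor or acceptor, on a saturated chain carbon. The expected step of a 1.0-fold higher number from compound 2 to compound 3 (0.00 log units; within the scatter) is therefore small and not beyond the scatter, in either direction. For compound 3 the estimate in this assay is 38000 nM, within 12000 nM to 120000 nM.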

Compound 3, half-maximal inhibitory concentration: 3250 nM
The estimate for compound 3 lay 12-fold (1.07 log units) above the measured number, and the stated range ends above it.
By their numbers in this assay, from the lowest: compounds 1 and 3 (each within the scatter of the next); then compound 2.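

In this assay, this position responds to a very small change: ethyl to isopropyl, a single methyl in place of hydrogen on the saturated chain carbon, gives a 12-fold lower number from compound 2 to compound 3 (1.07 log units; beyond the scatter) and so undoes most of what compound 2 lost. The earlier step exchanged the whole aryl group, whereas this one shows that the chain alone can decide the result, and 3-isopropylphenyl in place of 2-cyanophenyl gives a 1.6-fold higher number from compound 1 to compound 3 (0.22 log units; within the scatter), so a nitrile is not needed to reach this range among these three compounds. No measurement at hand explains this sensitivity to one methyl.

On these data alone, whether the trend continues with a tert-butyl group or a longer chain remains open. So does whether an amine or a carboxylic acid on that chain would be tolerated.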